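Pentyl in Place of Diethylamino: Expectation for Compound 4

This account rests on a few compounds, and the source may have more. Where it says the series, first, only, none or still open, it means among the compounds named here.

In a functional assay on XF498 cells (Homo sapiens) for antiproliferative activity, read by MTT assay, with a stated time of 96 h (on this read-out higher numbers stand for weaker inhibition and lower numbers for stronger inhibition), the three measured compounds give the following values:
compound 1, `CN(C)c1ccc(N2C(=O)NC3(CSC4=C3C(=O)c3ncccc3C4=O)C2=O)cc1`, 800 nM
compound 2, `O=C1C2=C(C(=O)c3ncccc31)C1(CS2)NC(=O)N(c2ccc(Cl)cc2)C1=O`, 590 nM
compound 3, `CCN(CC)c1ccc(N2C(=O)NC3(CSC4=C3C(=O)c3ncccc3C4=O)C2=O)cc1`, 730 nM

Compound 3 sits between the other two on these numbers, and all three lie within the scatter of one another: a 1.1-fold lower number from compound 1 to compound 3 (0.04 log units; within the scatter) and a 1.2-fold higher number from compound 2 to compound 3 (0.09 log units; within the scatter). Compound 4, `CCCCCc1ccc(N2C(=O)NC3(CSC4=C3C(=O)c3ncccc3C4=O)C2=O)cc1`, has not yet been measured in this assay. It differs from compound 3 at one place: pentyl in place of diethylamino on an aromatic carbon.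

Among the measured compounds shown here, two measured steps touch the same place. The step from dimethylamino to diethylamino, a 1.1-fold lower number from compound 1 to compound 3 (0.04 log units; within the scatter), and the step from chloro to diethylamino, a 1.2-fold higher number from compound 2 to compound 3 (0.09 log units; within the scatter), both stayed within the scatter, so three quite different groups at this place have given essentially one number. For the measured compounds named here, no measured compound carries pentyl or any comparable chain there, so the only guide is that this position has so far tolerated exchange without a step beyond the scatter. On that basis compound 4 is expected to show no step beyond the scatter, a 1.0-fold lower number from compound 3 to compound 4 (0.02 log units; within the scatter). The estimate for compound 4 in this assay is 700 nM, with a range from 350 nM to 1400 nM.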

Compound 4, half-maximal inhibitory concentration: 830 nM
Compound 4: middle estimate off by 1.2-fold (0.07 log units), on the low side; low and high end bracket the measured number.
By their numbers in this assay, from the lowest: compounds 2, 3, 1 and 4 (each within the scatter of the next).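

Among the compounds shown here, the pentyl of compound 4 gives the first comparison in this assay in which the group on this aromatic carbon, para to a large group, is an all-carbon chain, and the change removes the nitrogen and the hydrogen-bond acceptor of diethylamino while keeping the same count of heavy atoms. That exchange stays within the scatter (a 1.1-fold higher number from compound 3 to compound 4 (0.06 log units; within the scatter)), as do the comparisons with the chloro compound (a 1.4-fold higher number from compound 2 to compound 4 (0.15 log units; within the scatter)) and the dimethylamino compound (a 1.0-fold higher number from compound 1 to compound 4 (0.02 log units; within the scatter)), so among these four compounds neither the nitrogen nor the acceptor of the dialkylamino groups is needed to keep the number in this range, and none of the four goes against that reading. Nothing available explains why the four groups give numbers so close together.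

From the compounds shown here alone, it remains open whether a carboxylic acid, a primary amine, a hydroxyl or a chain much longer than pentyl at this place would also stay within the scatter. All four compounds share the same core and differ only at this one place, so they say nothing about how changes elsewhere in the core would affect the number.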